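The compounds below may be only part of what the source reports. "The series", "measured", "known", "first", "only" and "open" are said of these compounds alone.

The measured compounds:
compound 1, `COc1ccc(C2=NN(C(=O)C(C)Br)C(c3ccco3)C2)cc1OC`, 42%;
compound 2, `COc1ccc(C2CC(c3ccc(OC)c(OC)c3)=NN2C(=O)C(C)Br)c(OC)c1`, 69%;
compound 3, `COc1ccc(C2=NN(C(=O)C(C)O[N+](=O)[O-])C(c3ccco3)C2)cc1OC`, 42%.

In a functional assay on the whole organism (strain albino) for inhibition, with Rattus norvegicus as the target, read by paw edema, with stated times of 30 min and 3 h, at a dose of 100 mg/kg by the oral route (a higher number here means more inhibition at the dose given (going by the name of the read-out), a lower number less inhibition), compound 1 gives 42%, compound 2 gives 69% and compound 3 gives 42%. Compound 1 and compound 2 differ in one place: 2,4-dimethoxyphenyl in place of furan-2-yl on a saturated ring carbon. That change made the step of a number 27 percentage points higher from compound 1 to compound 2 (beyond the scatter). Compound 1 and compound 3 also differ in one place, and this is how the two cores differ: nitrooxy in place of bromo on a saturated chain carbon bound to a carbonyl carbon and a saturated chain carbon. Here the step was no change at the digits printed from compound 1 to compound 3 (within the scatter), so compound 3 stands level with compound 1, the two together being the lowest of the three numbers.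

Compound 4, `COc1ccc(C2CC(c3ccc(OC)c(OC)c3)=NN2C(=O)C(C)O[N+](=O)[O-])c(OC)c1`, has not yet been measured in this assay. It differs from compound 3 in one place: 2,4-dimethoxyphenyl in place of furan-2-yl on a saturated ring carbon. Within the data shown here, this is the same kind of change as the one between compound 1 and compound 2, though not the same: in the earlier pair the place is next to the ring atom that bears a (1-bromoethyl)carbonyl group (5 heavy atoms), whereas here it is next to the ring atom that bears a group of 8 heavy atoms. Among the measured compounds shown here, the one earlier instance of this change gave the step of a number 27 percentage points higher from compound 1 to compound 2 (beyond the scatter), and swapping bromo for nitrooxy left the value unchanged, as no change at the digits printed from compound 1 to compound 3 (within the scatter) shows, so a step of similar size is expected on the nitrooxy core. Compound 4 is therefore expected to show a number 25 percentage points higher from compound 3 to compound 4 (beyond the scatter), resting on the step of a number 27 percentage points higher from compound 1 to compound 2 (beyond the scatter). The estimate for compound 4 in this assay is 67%, between 52% and 82%.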

Compound 4, a percentage reported as inhibition, in the whole organism at one dose (the size of the read-out at that dose, not a potency): 56%
For compound 4 the middle estimate is 11 percentage points above the measured one; the range from low to high includes it.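

In this assay, the exchange of furan-2-yl for 2,4-dimethoxyphenyl also raised the number on the nitrooxy core, with a number 14 percentage points higher from compound 3 to compound 4 (beyond the scatter), and the step seen on the bromo core and this new one cannot be told apart in size: the same change on two cores in this assay, a number 27 percentage points higher (beyond the scatter) from compound 1 to compound 2 and a number 14 percentage points higher (beyond the scatter) from compound 3 to compound 4, 13 percentage points apart, within the scatter of two such steps. The exchange of bromo for nitrooxy, which had left the furan-2-yl core unchanged, gave a number 13 percentage points lower from compound 2 to compound 4 (beyond the scatter) on the 2,4-dimethoxyphenyl core, yet this step and the earlier one cannot be told apart either: the same change on two cores in this assay, no change at the digits printed (within the scatter) from compound 1 to compound 3 and a number 13 percentage points lower (beyond the scatter) from compound 2 to compound 4, 13 percentage points apart, within the scatter of two such steps. The four compounds thus show the aryl change carrying over in the same direction on both cores, but with one pair per core they do not show that its size is fixed, that the nitrooxy change truly depends on the core, or that either result would hold beyond these compounds.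

The compounds shown leave open how other groups would behave at the saturated ring carbon, such as an unsubstituted phenyl or a thiophene in place of furan-2-yl. They also leave open whether an amine or a carboxylic acid in place of bromo or nitrooxy on the chain would follow the same course.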